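Working notes: a triazole in place of a methylpyrazole

The source may report more compounds than this note shows. Statements on the series, on what has been measured and on what is new or still open speak of the compounds shown alone.

compound 1 `Cn1nccc1-c1cc(C(F)(F)F)ccc1[C@H]1CCOc2cc(S(=O)(=O)Nc3nccs3)ccc21`: 1300 nM
compound 2 `Cn1nccc1-c1cc(C(F)(F)F)ccc1[C@H]1CCOc2cc(S(=O)(=O)Nc3ncccn3)ccc21`: 2000 nM

In an ADME assay on the whole organism (Mus musculus, strain BALB/c) for pharmacokinetics, read by LC-MS, with a stated time of 24 h, at a dose of 1 mg/kg by the intravenous route (on this read-out lower numbers stand for lower exposure and higher numbers for higher exposure at the dose given), compound 1 gives 1300 nM, and this lies within the scatter of compound 2 at 2000 nM. With only these two numbers, compound 1 has a single measured neighbour. Compound 3 `O=S(=O)(Nc1nccs1)c1ccc2c(c1)OCC[C@@H]2c1ccc(C(F)(F)F)cc1-n1ccnn1` awaits measurement and departs from compound 1 at one place: 1H-1,2,3-triazol-1-yl in place of 1-methyl-1H-pyrazol-5-yl on an aromatic carbon. In words, 1H-1,2,3-triazol-1-yl stands in place of 1-methyl-1H-pyrazol-5-yl. Among the measured compounds shown here, the one measured step, a 1.5-fold higher number from compound 1 to compound 2 (0.19 log units; within the scatter), concerns a group on a sulfonamide nitrogen, a place that compound 3 leaves unchanged. For the measured compounds named here, no measured step therefore bears directly on this exchange, and the data give no direction for it. No change beyond the scatter is expected in this assay, and the expected step is a 1.1-fold lower number from compound 1 to compound 3 (0.03 log units; within the scatter). Compound 3 is estimated at 1200 nM, with an expected range of 500 nM to 2800 nM.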

Compound 3, maximal plasma concentration: 2200 nM
For compound 3 the middle estimate is 1.8-fold (0.26 log units) below the measured one; the measured number falls inside the stated range.
By their numbers in this assay, from the lowest: compounds 1, 2 and 3 (each within the scatter of the next).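

Working notes, result: at this aromatic carbon, ortho to a large group and meta to a trifluoromethyl group, exchanging 1-methyl-1H-pyrazol-5-yl for 1H-1,2,3-triazol-1-yl gives a 1.7-fold higher number from compound 1 to compound 3 (0.23 log units; within the scatter) in this assay. Among the compounds shown here, this is the first reading at this position, and it shows that a ring of 5 heavy atoms with 3 hydrogen-bond acceptors stays within the scatter of a ring of 6 heavy atoms with 2 on maximal plasma concentration. No supporting data are available to account for the result.

From the compounds shown here alone, whether an aminomethyl group or a carboxylic acid on this aromatic carbon would read beyond the scatter remains open. Also open, going by these compounds, is whether the same ring exchange reads alike with pyrimidin-2-yl on the sulfonamide nitrogen.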